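A few compounds are considered here, and "the series" means these few. Any claim that something is new, unique, unknown or untested is made for them only; others in the source may bear on it.

Of the compounds shown here, three with a shared core have been measured in a functional assay on HeLa cells (Homo sapiens) for antiproliferative activity, read by CCK-8 assay, with a stated time of 72 h, tested at 8 uM (on this read-out higher numbers stand for a stronger effect at the one concentration tested and lower numbers for a weaker effect), and frame the question. Compound 1 `Nc1ccccc1NC(=O)c1ccc(CSC(=S)N2CCN(c3ccc(Cl)cc3)CC2)cc1` gives 44.8% in this assay and stands lowest of the three numbers. Compound 2 `CN(Cc1ccncc1)C(=S)SCc1ccc(C(=O)Nc2ccccc2N)cc1` gives 72.7% in this assay, and compound 3 `CN(Cc1cccnc1)C(=S)SCc1ccc(C(=O)Nc2ccccc2N)cc1` gives 68.7% in this assay. The gap from compound 1 up to compound 3 lies beyond the scatter, and so does the gap from compound 1 up to compound 2. Within the data shown here, the only measured step between neighbours that differ in one place is a number 4 percentage points lower from compound 2 to compound 3 (within the scatter) and it lies within the scatter.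

Compound 4 `Nc1ccccc1NC(=O)c1ccc(CSC(=S)N2CCN(c3cnccn3)CC2)cc1` has not yet been measured in this assay. It differs from compound 1 by pyrazin-2-yl in place of 4-chlorophenyl on an amine nitrogen in a ring and by nothing else. Among the measured compounds shown here, no measured step touches this place: the step from compound 2 to compound 3 swaps a group on a saturated chain carbon bound to an amide-type nitrogen, not on the amine nitrogen in a ring, and it was within the scatter in any case. For the measured compounds named here, there is thus no step on which to ground a direction. What is expected is a number 0.2 percentage points higher from compound 1 to compound 4 (within the scatter) and so nothing beyond the scatter. The estimate for compound 4 in this assay is 45% with a range from 25% to 65%.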

Compound 4, a percentage reported as inhibition, at one concentration (the size of the read-out at that concentration, not a potency): 76.9%
For compound 4 the middle estimate is 31.9 percentage points below the measured one; the measured number lies above the stated range.
By their numbers in this assay, from the lowest: compound 1; then compounds 3, 2 and 4 (each within the scatter of the next).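

In this assay, among these compounds, pyrazin-2-yl in place of 4-chlorophenyl on the amine nitrogen in a ring brought a number 32.1 percentage points higher from compound 1 to compound 4 (beyond the scatter) and so gave the first measured single-place change here that lies beyond the scatter. This shows that the read-out at the one concentration tested depends on the group at this place, three ring bonds from the ring nitrogen, and that a six-membered aromatic ring of carbon only is not interchangeable there with a six-membered aromatic ring with 2 hetero atoms. No measurement shown here accounts for the size or direction of this step, and its cause remains unassigned.

The single swap removes the chlorine and brings in the ring nitrogens together, so the compounds shown leave open which of these changes goes with the higher number; a plain phenyl or a pyridin-2-yl on the same amine nitrogen would help to separate the two. They also leave open how compound 1 and compound 4 compare in potency, since each has a read-out at only one concentration.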